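Chloromethyl for 2-chloroethoxy on the carbonyl carbon

A few compounds are considered here, and "the series" means these few. Any claim that something is new, unique, unknown or untested is made for them only; others in the source may bear on it.

In a functional assay on K562 cells (Homo sapiens) for antiproliferative activity, read by MTT assay (on this read-out higher numbers stand for weaker inhibition and lower numbers for stronger inhibition), compound 1 `COC(=O)N1CCCc2cc(S(=O)(=O)N3CC(c4ccccc4)NC3=O)ccc21` stands at > 20000 nM as a limit of the assay. Among the compounds with values here, compound 2 `O=C(OCCCl)N1CCCc2cc(S(=O)(=O)N3CC(c4ccccc4)NC3=O)ccc21` gives 10600 nM as the only actual number so far. In compound 3 `O=C(CCl)N1CCCc2cc(S(=O)(=O)N3CC(c4ccccc4)NC3=O)ccc21` chloromethyl takes the place of 2-chloroethoxy on a carbonyl carbon (chloromethyl in place of 2-chloroethoxy on a carbonyl carbon). Within the data shown here, only one measured step bears on this, an at least 1.8-fold lower number from compound 1 to compound 2 (0.27 log units; that floor lies within the scatter), and it offers weak guidance. A modest move towards a lower number is therefore expected, with the estimated step being a 2.7-fold lower number from compound 2 to compound 3 (0.42 log units; beyond the scatter) in this assay. For compound 3 the estimate is 4000 nM with an expected range from 600 nM to 20000 nM.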

Compound 3, half-maximal inhibitory concentration: 1100 nM
For compound 3 the middle estimate is 3.6-fold (0.56 log units) above the measured one, within the range that was stated.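

In this assay, chloromethyl in place of 2-chloroethoxy on the carbonyl carbon gives a 9.6-fold lower number from compound 2 to compound 3 (0.98 log units; beyond the scatter), so the number responds to this change beyond the scatter, which the earlier step, with its floor within the scatter, could not show. Measured against methoxy on the same carbon, chloromethyl gives an at least 18-fold lower number from compound 1 to compound 3 (1.25 log units; beyond the scatter). That step is only a floor, as compound 1 is held at a limit: the limit of > 20000 nM in this assay, at which 1 of the 3 values shown sits.

The compounds shown leave open what the chlorine contributes, a question that a plain methyl or a bromomethyl on this carbonyl carbon would address. As far as these compounds go, whether a longer chain, such as 3-chloropropyl, would keep the lower number also stays open.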